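This account rests on a few compounds, and the source may have more. Where it says the series, first, only, none or still open, it means among the compounds named here.

compound 1 `CC(C)CN(c1cccc(F)c1)S(=O)(=O)c1ccc2c(c1)C(=O)CC(C1CCOCC1)O2`: 3.5
compound 2 `CC(C)CN(c1ccccc1F)S(=O)(=O)c1ccc2c(c1)C(=O)CC(C1CCOCC1)O2`: 3.44

In a physicochemical assay for lipophilicity, at pH 7.4 (on this read-out lower numbers stand for lower lipophilicity and higher numbers for higher lipophilicity), compound 2 and compound 1 lie within the scatter of each other, so neither stands apart. Compound 3 `CC(C)CN(c1ccc(F)cc1F)S(=O)(=O)c1ccc2c(c1)C(=O)CC(C1CCOCC1)O2` differs from compound 2 by fluoro in place of hydrogen on an aromatic carbon, which is fluoro in place of hydrogen on an aromatic carbon, taking 2-fluorophenyl to 2,4-difluorophenyl. For the measured compounds named here, the one measured step, a number 0.06 log units lower from compound 1 to compound 2 (within the scatter), swaps one fluorophenyl for another, so it is only a loose guide to this change. The expected size is a number 0.11 log units higher from compound 2 to compound 3 (within the scatter), a small rise that stays within the scatter. For compound 3 the estimated value is 3.55, with an expected range of 3.3 to 3.8.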

Compound 3, distribution coefficient: 3.62
Compound 3: middle estimate off by 0.07 log units, on the low side, and the stated range covers the measured number.
By their numbers in this assay, from the lowest: compounds 2, 1 and 3 (each within the scatter of the next).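

In this assay, fluoro in place of hydrogen on the aromatic carbon para to a large group gives a number 0.18 log units higher from compound 2 to compound 3 (within the scatter), so adding this fluoro does not set the new compound apart. Replacing 3-fluorophenyl with 2,4-difluorophenyl on the sulfonamide nitrogen gives a number 0.12 log units higher from compound 1 to compound 3 (within the scatter), so a second fluoro on this ring also stays inside the scatter, something the earlier swap between two fluorophenyl groups could not show. No supporting information bears on these readings. The compounds shown leave open whether an amine or a carboxylic acid at this position would move the number beyond the scatter.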